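Solubility outlook for compound 4 after a ring swap

The source may report more compounds than this note shows. Statements on the series, on what has been measured and on what is new or still open speak of the compounds shown alone.

Compound 1 `CN(c1ccccc1)c1cnc(NCc2c(F)ccc3c2CCO3)n2cnnc12` is reported in a physicochemical assay for solubility, read by LC-MS, in phosphate buffer, with a stated time of 24 h, at pH 7.4 (on this read-out lower numbers stand for lower solubility and higher numbers for higher solubility), only as < 2000 nM, a limit rather than a number.
Compound 2 `CC1(C)CC(=O)N(c2cnc(NCc3c(F)ccc4c3CCO4)n3cnnc23)C1` gives 57000 nM in this assay.
Compound 3 `O=C1CC2(CC2)CN1c1cnc(NCc2c(F)ccc3c2CCO3)n2cnnc12` gives 130000 nM in this assay.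

Compound 3 stands highest of the two numbers; its nearest neighbour is compound 2, with a 2.3-fold higher number from compound 2 to compound 3 (0.36 log units; beyond the scatter). Compound 4 `O=C(Nc1cnc(NCc2c(F)ccc3c2CCO3)n2cnnc12)c1cccnc1` differs from compound 3 by a group of 9 heavy atoms (6 carbon, 2 nitrogen, 1 oxygen; one six-membered aromatic ring with 1 hetero atom) in place of a group of 8 heavy atoms (6 carbon, 1 nitrogen, 1 oxygen; one three-membered non-aromatic ring of carbon only, one five-membered non-aromatic ring with 1 hetero atom), on an aromatic carbon. The most relevant measured step is an at least 65-fold higher number from compound 1 to compound 3 (1.81 log units; beyond the scatter), where removing a group containing an aromatic ring went with a large rise. Compound 4 brings an aromatic ring back, so a drop beyond the scatter is expected, though smaller than that step. Compound 4 is estimated at 20000 nM, between 3000 nM and 90000 nM, which would mean the expected step of a 6.5-fold lower number from compound 3 to compound 4 (0.81 log units; beyond the scatter).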

Compound 4, solubility: 12000 nM
For compound 4 the middle estimate is 1.7-fold (0.22 log units) above the measured one; the measured number falls inside the stated range.
By their numbers in this assay, from the lowest: compound 4; then compound 2; then compound 3. At a limit, below all of these: compound 1.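

In this assay, the ((pyridin-3-yl)carbonyl)amino group gives a lower number than either non-aromatic ring group at this position: an 11-fold lower number from compound 3 to compound 4 (1.03 log units; beyond the scatter), and a 4.8-fold lower number from compound 2 to compound 4 (0.68 log units; beyond the scatter). An aromatic ring here does not by itself bring the number down to that of the methyl(phenyl)amino group, with an at least 6.0-fold higher number from compound 1 to compound 4 (0.77 log units; beyond the scatter). Compound 1 is known only as a limit: the limit of < 2000 nM in this assay, at which 1 of the 4 values shown sits.

The compounds shown do not separate the part played by the pyridin-3-yl ring from that of the amide hydrogen. An acetylamino group or a benzoylamino group at this position would help to tell the two apart.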